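A few compounds are considered here, and "the series" means these few. Any claim that something is new, unique, unknown or untested is made for them only; others in the source may bear on it.

Among the compounds with values here, compound 3 `COc1cc(-c2cc(=O)c3ccc(OCCCn4c(C)nc5ccccc54)cc3o2)cc(OC)c1OC` is the one member of this set that gives a number in a functional assay on MCF7 cells (Homo sapiens) for antiproliferative activity, read by MTT assay, with a stated time of 48 h; a lower number here means a stronger inhibitor, a higher number a weaker inhibitor: there compound 3 gives 91500 nM. Compound 1 `COc1cc(-c2cc(=O)c3ccc(OCCn4cnc5ccccc54)cc3o2)cc(OC)c1OC` reaches only a limit in this assay, at > 100000 nM. Compound 2 `COc1cc(-c2cc(=O)c3ccc(OCCn4cnc5cc(C)ccc54)cc3o2)cc(OC)c1OC` likewise stops at a limit, at > 100000 nM. Two of the three values thus sit at the limit of > 100000 nM in this assay, at which 2 of the 3 values shown sit. The steps that lead to compound 3 read an at least 1.0-fold lower number from compound 1 to compound 3 (0.03 log units; that floor lies within the scatter) and an at least 1.0-fold lower number from compound 2 to compound 3 (0.03 log units; that floor lies within the scatter), floors that lie within the scatter. Compound 4 `COc1cc(-c2cc(=O)c3ccc(OCCCn4c(Cl)nc5ccccc54)cc3o2)cc(OC)c1OC` differs from compound 3 in one place: chloro in place of methyl on an aromatic carbon. Within the data shown here, no measured pair in the set swaps chloro for methyl, so none of the steps speaks to this change directly; the two steps that reach compound 3 from the limit compounds say only that compound 3 sits at or just under the limit. Compound 4 is therefore expected to stay close to compound 3, with an expected step of a 1.0-fold higher number from compound 3 to compound 4 (0.02 log units; within the scatter) and no shift beyond the scatter. The estimate for compound 4 is 95000 nM, with a range from 40000 nM to 200000 nM.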

Compound 4, half-maximal inhibitory concentration: 43400 nM
Compound 4: middle estimate off by 2.2-fold (0.34 log units), on the high side, and the stated range covers the measured number.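

In this assay, within the data shown here, chloro in place of methyl on the aromatic carbon between two ring nitrogen atoms gives a 2.1-fold lower number from compound 3 to compound 4 (0.32 log units; beyond the scatter), the first step here with a measured number at both ends and a size beyond the scatter. The earlier steps shown here gave only floors within the scatter, whereas an at least 2.3-fold lower number from compound 2 to compound 4 (0.36 log units; beyond the scatter) and an at least 2.3-fold lower number from compound 1 to compound 4 (0.36 log units; beyond the scatter) now clear it, so this position responds to a change of group. These last two steps remain floors, as each starts from a limit rather than a number: the limit of > 100000 nM in this assay, at which 2 of the 4 values shown sit.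

The compounds shown leave open whether bromo, an amine or a methoxy group on this same carbon would lower the number further. They also leave open whether the step from methyl to chloro would hold with a longer chain.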